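A chloro swap on a slowly cleared compound

The compounds below may be only part of what the source reports. "The series", "measured", "known", "first", "only" and "open" are said of these compounds alone.

Compound 1 `Cc1ccc([C@@H](C)Oc2cc3onc(CCC(=O)O)c3cc2Cl)nc1`: 1.1 mL/min/kg
Compound 2 `O=C(O)CCn1c(=O)oc2cc(OCC3CC3)c(Cl)cc21`: 4.1 mL/min/kg

In an ADME assay on the whole organism (blood, strain Han-Wistar) for pharmacokinetics, with Rattus norvegicus as the target, read by LC-MS, at a dose of 1 mg/kg by the intravenous route (a lower number here means slower removal, a higher number faster removal of the compound), compound 1 stands lowest of the two at 1.1 mL/min/kg and compound 2 stands higher at 4.1 mL/min/kg with a gap beyond the scatter. Compound 3 `C[C@@H](Oc1cc2onc(CCC(=O)O)c2cc1Cl)c1ccc(Cl)cn1` keeps the core of compound 1 but carries chloro in place of methyl on an aromatic carbon and so 5-methylpyridin-2-yl becomes 5-chloropyridin-2-yl. Going by the values given here, no measured pair shows this swap, so in this assay no step beyond the scatter is expected, starting from compound 1 at 1.1 mL/min/kg as the only close reference. The estimated step is modest (a 1.1-fold lower number from compound 1 to compound 3 (0.04 log units; within the scatter)). For compound 3 the estimate is 1 mL/min/kg with an expected range from 0.45 mL/min/kg to 2.3 mL/min/kg as the likely span.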

Compound 3, clearance: 0.35 mL/min/kg
Compound 3: middle estimate off by 2.9-fold (0.46 log units), on the high side; the measured number lies below the stated range.
By their numbers in this assay, from the lowest: compound 3; then compound 1; then compound 2.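

In this assay, replacing 5-methylpyridin-2-yl with 5-chloropyridin-2-yl gives a 3.1-fold lower number from compound 1 to compound 3 (0.50 log units; beyond the scatter), so changing one heavy atom on this aromatic carbon, para to a large group, still lowers an already low number. Going by these compounds alone, the earlier compounds offered no pair differing in one place, so this is the first sign that this position affects removal from the blood. No measurement here explains the drop. The compounds shown leave open whether fluoro, nitrile or methoxy on this same carbon would lower the number too. As far as these compounds go, whether the swap acts alike on another core also remains open.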